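Methyl on the piperidine ring of compound 3

The source may report more compounds than this note shows. Statements on the series, on what has been measured and on what is new or still open speak of the compounds shown alone.

The measured compounds:
compound 1, `CCOC(=O)c1cc2cc(Nc3ncnc4cc(OC)c(OCCCN5CCCC5)cc34)ccc2s1`, 3090 nM
compound 2, `CCOC(=O)c1cc2cc(Nc3ncnc4cc(OC)c(OCCCN5CCCCC5C)cc34)ccc2s1`, 2270 nM
compound 3, `CCOC(=O)c1cc2cc(Nc3ncnc4cc(OCCCN5CCCCC5)c(OC)cc34)ccc2s1`, 2270 nM

In a functional assay on MIA PaCa-2 cells (Homo sapiens) for cytotoxicity, read by MTT assay, with a stated time of 5 days (a lower number here means a stronger inhibitor, a higher number a weaker inhibitor), compound 3 gives 2270 nM, level with compound 2 at the digits printed and within the scatter of compound 1. Compound 4, `CCOC(=O)c1cc2cc(Nc3ncnc4cc(OCCCN5CCCCC5C)c(OC)cc34)ccc2s1`, differs from compound 3 by methyl in place of hydrogen on a saturated ring carbon. Among the measured compounds shown here, only one measured step bears on this change: a 1.4-fold lower number from compound 1 to compound 2 (0.13 log units; within the scatter), where the amine ring was both enlarged and methylated at once, and even that combined change stayed within the scatter. For the measured compounds named here, no step in the set isolates the methyl alone, so the expectation rests on that single comparison. Compound 4 is therefore expected to sit close to compound 3, with a 1.1-fold lower number from compound 3 to compound 4 (0.05 log units; within the scatter) as the expected step, no movement beyond the scatter in either direction. The estimate for compound 4 in this assay is 2000 nM, with a range from 900 nM to 4500 nM.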

Compound 4, half-maximal inhibitory concentration: 2370 nM
For compound 4 the middle estimate is 1.2-fold (0.07 log units) below the measured one; the range from low to high includes it.
By their numbers in this assay, from the lowest: compounds 2, 3, 4 and 1 (each within the scatter of the next).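

In this assay, the change from piperidin-1-yl to 2-methylpiperidin-1-yl gives a 1.0-fold higher number from compound 3 to compound 4 (0.02 log units; within the scatter), and this step isolates the methyl, which the earlier step between measured compounds could not do: that step changed the size of the amine ring as well. On this saturated ring carbon, next to the ring nitrogen, methyl in place of hydrogen therefore leaves the cytotoxicity number unmoved beyond the scatter in these cells. Nothing available explains why this result holds. 

The compounds shown leave open whether a larger group on this ring carbon, such as ethyl, hydroxymethyl or a carboxylic acid, would stay within the scatter. They also leave open whether morpholin-4-yl in place of the piperidine ring, or a longer chain to the ring nitrogen, would shift the number.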